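This account rests on a few compounds, and the source may have more. Where it says the series, first, only, none or still open, it means among the compounds named here.

Compound 3 `CC(C)(Oc1ccccc1O)C1OCC(C/C=C\CCC(=O)O)C(c2cccnc2)O1` in an assay for inhibition of prostacyclin synthase (Homo sapiens), using microsomes (on this read-out higher numbers stand for weaker inhibition and lower numbers for stronger inhibition), gives only a limit, > 100000 nM. Compound 1 `Cc1ccc(C#N)c(OC(C)(C)C2OCC(C/C=C\CCC(=O)O)C(c3cccnc3)O2)c1` likewise gives only a limit in this assay, > 100000 nM. Compound 2 `COc1ccc(OC(C)(C)C2OCC(C/C=C\CCC(=O)O)C(c3cccnc3)O2)cc1` gives only a limit as well, > 100000 nM. With every value sitting at the limit of > 100000 nM in this assay, at which 3 of the 3 values shown sit, the steps a step that the two limits leave unreadable from compound 1 to compound 2, a step that the two limits leave unreadable from compound 1 to compound 3 and a step that the two limits leave unreadable from compound 2 to compound 3 cannot be sized, so the aryl ether variations measured so far carry no readable information. Compound 4 `CC(C)(Oc1ccccc1[N+](=O)[O-])C1OCC(C/C=C\CCC(=O)O)C(c2cccnc2)O1` differs from compound 3 by nitro in place of hydroxy on an aromatic carbon. For the measured compounds named here, no measured step bears on this change, and nothing shows any aryl group bringing inhibition into the readable range. Compound 4 is expected to remain at the limit, and the estimated step is a step that the limit leaves unreadable from compound 3 to compound 4. The estimate for compound 4 in this assay is 150000 nM, with a range from 30000 nM to 1000000 nM.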

Compound 4, half-maximal inhibitory concentration: < 1000 nM
Compound 4 gave a limit, no number (the forecaster's own chance of this, stated with the estimate: 85%); middle value at least 150-fold (2.17 log units) away from the limit.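

In this assay, for the compounds shown here, compound 4 gives < 1000 nM, a limit and not a number, and the only value on that side of the series: the limit of < 1000 nM in this assay, at which 1 of the 4 values shown sits. Nitro in place of hydroxy, on an aromatic carbon ortho to a large group, gives an at least 100-fold lower number from compound 3 to compound 4 (2.00 log units; beyond the scatter), the first readable step. Going by these compounds alone, the 2-nitrophenyl group also gives an at least 100-fold lower number from compound 2 to compound 4 (2.00 log units; beyond the scatter) and an at least 100-fold lower number from compound 1 to compound 4 (2.00 log units; beyond the scatter), while the earlier steps among the other three aryl ethers cannot be read.

From the compounds shown here alone, how far compound 4 lies past its limit remains open. Also open, going by these compounds, is whether an amine or a carboxylic acid in place of nitro would keep this gain.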